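This account rests on a few compounds, and the source may have more. Where it says the series, first, only, none or still open, it means among the compounds named here.

Notes on the series. The compounds share one core, seen in compound 1 `Cc1ncn2c(O)nncc12`, compound 2 `Cc1nc(C(C)C)n2c(S)nncc12` and compound 3 `CCCc1ncn2c(S)nncc12`, and differ in the groups carried on it. All have been run in a functional assay for inhibition, with Homo sapiens as the target; a lower number here means a stronger inhibitor, a higher number a weaker inhibitor. In this assay compound 1 returns only a limit, > 48000 nM, not a number. Compound 2 likewise reaches only the limit of this assay, > 48000 nM. For compound 3 this assay again gives a limit, > 48000 nM, so compound 3 stands exactly where every value shown stands: the limit of > 48000 nM in this assay, at which 3 of the 3 values shown sit. Going by the values given here, no two measured compounds differ in one place, so no measured step is available.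

The next compound, compound 4 `Cc1ncn2c(S)nncc12`, follows from compound 3 by one change: hydrogen in place of ethyl on a saturated chain carbon bound to an aromatic carbon. Cut one bond further out, the same difference reads propyl to methyl. Among the compounds with values here, with no measured step to lean on and every value shown sitting at the limit of this assay, the step from compound 3 to compound 4 in this assay is expected to be none beyond the scatter, and compound 4 is expected to return a limit rather than a number. The expected step is a step that the limit leaves unreadable from compound 3 to compound 4. For compound 4 the estimate in this assay is 60000 nM, with a range from 20000 nM to 200000 nM.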

Compound 4, half-maximal inhibitory concentration: > 48000 nM
Compound 4 gave a limit, no number (the forecaster's own chance of this, stated with the estimate: 85%); the middle value lies beyond the limit too.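

Compound 4 returns only a limit in this assay, so no new step can be read from compound 1, compound 2 or compound 3 to compound 4. The series stands at a single point: the limit of > 48000 nM in this assay, at which 4 of the 4 values shown sit.

The compounds shown leave open whether any group on the shared core gives a measurable value in this assay.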